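The source may report more compounds than this note shows. Statements on the series, on what has been measured and on what is new or still open speak of the compounds shown alone.

Series notes. Compound 2 `N#Cc1cccc(-c2cc(COC(Cc3cn(C4CCN(Cc5ccc([N+](=O)[O-])cc5)CC4)nn3)c3ccc(Br)cc3)on2)c1` is the 3-cyanophenyl analogue of compound 1 `O=[N+]([O-])c1ccc(CN2CCC(n3cc(CC(OCc4cc(-c5ccc(F)cc5)no4)c4ccc(Br)cc4)nn3)CC2)cc1`. In a functional assay on HCT-116 cells (Homo sapiens) for cytotoxicity, with a stated time of 48 h (a higher number here means a weaker inhibitor, a lower number a stronger inhibitor), compound 1 gives only the assay limit > 25000 nM. In this assay compound 2 likewise gives only the assay limit > 25000 nM, so compound 2 stands at the limit, not at a number. The step that the two limits leave unreadable from compound 1 to compound 2 is therefore unreadable; both values sit at the limit of > 25000 nM in this assay, at which 2 of the 2 values shown sit. Compound 3 `O=[N+]([O-])c1ccc(CN2CCC(n3cc(CC(OCc4cc(-c5ccccc5F)no4)c4ccc(Br)cc4)nn3)CC2)cc1` differs from compound 2 by 2-fluorophenyl in place of 3-cyanophenyl on an aromatic carbon. No readable step bears on this exchange of aryl groups. Compound 3 is expected to stay at the limit, an estimated step that the limit leaves unreadable from compound 2 to compound 3. For compound 3 the estimate in this assay is 30000 nM, range 15000 nM to 100000 nM.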

Compound 3, half-maximal inhibitory concentration: 9000 nM
The estimate for compound 3 lay 3.3-fold (0.52 log units) above the measured number; measured number outside the range, below it.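

In this assay the aryl group on this aromatic carbon of the five-membered ring does move the read-out: 2-fluorophenyl in place of 3-cyanophenyl gives an at least 2.7-fold lower number from compound 2 to compound 3 (0.44 log units; beyond the scatter) and 2-fluorophenyl in place of 4-fluorophenyl gives an at least 2.7-fold lower number from compound 1 to compound 3 (0.44 log units; beyond the scatter). Compound 1 and compound 3 both carry a fluorophenyl, so the presence of fluorine alone does not separate them. The step between compound 1 and compound 2 still cannot be read, and both new steps are bounds, not sizes: the limit of > 25000 nM in this assay, at which 2 of the 3 values shown sit.

Open, on these data alone, is how unsubstituted phenyl, 2-chlorophenyl or 2-methoxyphenyl would read at this place.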